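This account rests on a few compounds, and the source may have more. Where it says the series, first, only, none or still open, it means among the compounds named here.

Measured in an ADME assay (liver) for metabolic stability, with Liver microsome (Rattus norvegicus) as the target, read by LC-MS, using microsomes, with a stated time of 30 min, tested at 4 uM; on this read-out higher numbers stand for a more stable compound and lower numbers for a less stable compound:

compound 1 `Cc1nc(N2CCN(C)CC2)c2nc(-c3ccccc3Cl)n(C3CC3)c2n1`: 44%
compound 2 `Cc1nc(N2CCN(C)CC2)c2nc(-c3cccc(Cl)c3)n(C3CCOCC3)c2n1`: 45%

These two compounds make up all the data so far. In this assay compound 2 gives 45% and compound 1 gives 44%, so the two numbers lie within the usual scatter of each other and neither can be set apart from the other.

The next compound to be tested is compound 3 `Cc1nc(N2CCN(C)CC2)c2nc(-c3ccccc3C(F)(F)F)n(C3CCOCC3)c2n1`. It carries 2-(trifluoromethyl)phenyl in place of 3-chlorophenyl on an aromatic carbon, and the new group sits next to the ring atom that bears an oxan-4-yl group.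

Within the data shown here, no two measured compounds differ in one place only, so the data do not show how such a change moves the read-out. The expectation therefore starts from compound 2 at 45% and assumes no step beyond the scatter, in either direction. The expected step is a number 2 percentage points higher from compound 2 to compound 3 (within the scatter) and it remains a weakly supported estimate.

Compound 3 is estimated at 47% in this assay with an expected range from 27% to 67%.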

Compound 3, percent of the compound remaining: 38%
Compound 3: the middle estimate sits 9 percentage points above what was measured, within the range that was stated.
By their numbers in this assay, from the lowest: compounds 3, 1 and 2 (each within the scatter of the next).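

Among these compounds, at this position, on an aromatic carbon of a five-membered aromatic ring with 2 nitrogen, next to the ring atom that bears an oxan-4-yl group, compound 2 and compound 3 give the first comparison in this assay of compounds that differ in one place only. Putting 2-(trifluoromethyl)phenyl in place of 3-chlorophenyl gives a number 7 percentage points lower from compound 2 to compound 3 (within the scatter), so this pair cannot be told apart on this read-out, even though the entering group has 10 heavy atoms and the leaving group 7. Nothing available explains how this change acts on the read-out.

This single step changes both the substituent on the phenyl ring and its place on that ring, so the compounds shown do not separate the effect of swapping chlorine for trifluoromethyl from the effect of moving it. Going by these compounds, how the read-out would respond at this position to a plain phenyl or a pyridine ring, or to a larger change such as a carboxylic acid on the phenyl ring, also remains open.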